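The compounds below may be only part of what the source reports. "The series", "measured", "known", "first", "only" and "open" are said of these compounds alone.

Measured compounds:
Compound 1 `COc1ccc(-c2cc(N3CCC(CCNS(N)(=O)=O)CC3)ncn2)cc1` gives 72300 nM in a functional assay on HT-29 cells (Homo sapiens) for antiproliferative activity, read by sulforhodamine B assay, with a stated time of 48 h; on this read-out higher numbers stand for weaker inhibition of growth and lower numbers for stronger inhibition of growth.
Compound 2 `NS(=O)(=O)NCCC1CCN(c2cc(-c3ccc(Cl)cc3)ncn2)CC1` gives 30500 nM in this assay.
Compound 3 `NS(=O)(=O)NCCC1CCN(c2cc(-c3ccc(C(F)(F)F)cc3)ncn2)CC1` gives 22600 nM in this assay.

Among these three numbers compound 2 stands second highest: it sits a 2.4-fold lower number from compound 1 to compound 2 (0.37 log units; beyond the scatter), while compound 2 and compound 3 are within the scatter of each other, as a 1.3-fold lower number from compound 2 to compound 3 (0.13 log units; within the scatter) shows. Compound 4 `NS(=O)(=O)NCCC1CCN(c2cc(-c3ccccc3F)ncn2)CC1` differs from compound 2 by 2-fluorophenyl in place of 4-chlorophenyl on an aromatic carbon.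

The measured steps all concern the group on the phenyl ring: a 2.4-fold lower number from compound 1 to compound 2 (0.37 log units; beyond the scatter) and a 3.2-fold lower number from compound 1 to compound 3 (0.51 log units; beyond the scatter) are modest shifts, and the change between chloro and trifluoromethyl stays within the scatter. None of them tests a fluorophenyl with the substituent at its second position, so the bearing of these steps is indirect. Because compound 1 gives 72300 nM when the chloro of compound 2 is swapped out, a modest weakening is expected for compound 4, though with wide uncertainty. Compound 4 is expected to give 60000 nM, with a range of 25000 nM to 150000 nM, corresponding to an estimated step of a 2.0-fold higher number from compound 2 to compound 4 (0.29 log units; within the scatter).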

Compound 4, concentration for 50% growth inhibition: 51800 nM
Estimate against measurement, compound 4: 1.2-fold (0.06 log units) above; low and high end bracket the measured number.
By their numbers in this assay, from the lowest: compounds 3, 2, 4 and 1 (each within the scatter of the next, the first and the last beyond it).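

Compound 4 brings the first 2-fluorophenyl to this place on the shared core, so both the halogen and its place on the phenyl ring differ from the 4-chlorophenyl of compound 2. In this assay this swap gives little that can be told apart from the usual scatter (a 1.7-fold higher number from compound 2 to compound 4 (0.23 log units; within the scatter)), and the same holds for the swap from 4-methoxyphenyl (a 1.4-fold lower number from compound 1 to compound 4 (0.14 log units; within the scatter)), although compound 1 and compound 2 do stand apart (a 2.4-fold lower number from compound 1 to compound 2 (0.37 log units; beyond the scatter)). No measurement shown accounts for these numbers.

The effects of the halogen and of its place on the phenyl ring remain tangled, and a 4-fluorophenyl or a 2-chlorophenyl would help to separate them. From the compounds shown here alone, how an amine or a carboxylic acid on the phenyl ring would fare also remains open.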